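Swapping a bromophenyl for a methoxy-methylphenyl

The source may hold more compounds than are shown below. What is called first, only, known or untested is meant among the compounds shown, and "the series" means these compounds.

Measured so far:
Compound 1 `CCCCc1ccc(-c2cc(=O)c3c(o2)C(CC)(CC)C(=O)C(CC)=C3O)cc1` — 111 uM
Compound 2 `CCC1=C(O)c2c(oc(-c3ccc(Br)cc3)cc2=O)C(CC)(CC)C1=O` — > 48.1 uM
Compound 3 `CCC1=C(O)c2c(oc(-c3ccccc3C(F)(F)F)cc2=O)C(CC)(CC)C1=O` — 45.6 uM

Three compounds share one core and differ only in the aryl group attached to it. In a functional assay on KB cells (Homo sapiens) for antiproliferative activity, read by sulforhodamine B assay, with a stated time of 3 days (on this read-out lower numbers stand for an effect already at smaller amounts and higher numbers for an effect only at larger amounts of compound), compound 1 gives 111 uM and compound 3 gives 45.6 uM, both weak. For compound 2 the result is a limit of the assay, > 48.1 uM, not a number; it sits at the limit of > 48.1 uM in this assay, at which 1 of the 3 values shown sits. Among the compounds with values here, the only single-site step among the measured compounds is a step that the limit leaves unreadable from compound 1 to compound 2, which that limit leaves unreadable, so no measured step says how a change on this aryl group moves the read-out.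

Compound 4 `CCC1=C(O)c2c(oc(-c3ccc(OC)c(C)c3)cc2=O)C(CC)(CC)C1=O` is not yet measured. It differs from compound 2 by 4-methoxy-3-methylphenyl in place of 4-bromophenyl on an aromatic carbon. Within the data shown here, with compound 2 known only as a limit and the one comparable step unreadable, no direction can be read from the numbers; all three measured values lie in the weak range, and compound 4 is expected to land there too. The estimated step that the limit leaves unreadable from compound 2 to compound 4 carries wide uncertainty. Compound 4 is estimated at 60 uM, with a range from 20 uM to 200 uM.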

Compound 4, concentration for half-maximal effect: 28.5 uM
Beside the measured number, compound 4's estimate is 2.1-fold (0.32 log units) above it; the measured number falls inside the stated range.
By their numbers in this assay, from the lowest: compounds 4 and 3 (each within the scatter of the next); then compound 1.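

Within the data shown here, on this aryl group, this assay now gives a first step with a direction: 4-methoxy-3-methylphenyl in place of 4-bromophenyl brings an at least 1.6-fold lower number from compound 2 to compound 4 (0.22 log units; that floor lies within the scatter). This gives only a floor, and with that floor inside the scatter, the swap is not yet shown to be a real gain, although the new group does give a measured number where the 4-bromophenyl compound gave none. Compound 2 remains a limit of the assay and not a number: the limit of > 48.1 uM in this assay, at which 1 of the 4 values shown sits.

The entering group brings a methoxy and a methyl together, so the compounds shown cannot say what either one does alone. As far as these compounds go, how an amine or a carboxylic acid on this phenyl ring would move the read-out also stays open.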